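Replacing 1H-imidazol-1-yl with pyridin-3-yl on an aromatic carbon

A few compounds are considered here, and "the series" means these few. Any claim that something is new, unique, unknown or untested is made for them only; others in the source may bear on it.

In a functional assay on VCaP cells (Homo sapiens) for antiproliferative activity, read by CCK-8 assay, with a stated time of 6 days (a higher number here means a weaker inhibitor, a lower number a stronger inhibitor), the three measured compounds stand as follows:
Compound 1 `CCN(c1ccc(C#N)c(Cl)c1)c1cc(-c2cccs2)ccc1C` shows "not determined" (no result reported)
Compound 2 `CCN(c1ccc(C#N)c(Cl)c1)c1cc(-n2cccn2)ccc1C` shows 2340 nM
Compound 3 `CCN(c1ccc(C#N)c(Cl)c1)c1cc(-n2ccnc2)ccc1C` shows > 30000 nM (a limit of the assay)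

Compound 3 rests on the limit of > 30000 nM in this assay, at which 1 of the 3 values shown sits, and so carries a limit, not a number. The next step, to compound 4 `CCN(c1ccc(C#N)c(Cl)c1)c1cc(-c2cccnc2)ccc1C`, puts pyridin-3-yl in place of 1H-imidazol-1-yl on an aromatic carbon, meta to a large group and para to a methyl group, and pyridin-3-yl in place of 1H-imidazol-1-yl on an aromatic carbon gives the counts of that change. Within the data shown here, the only measured step at this place is an at least 12-fold higher number from compound 2 to compound 3 (1.10 log units; beyond the scatter) and it is large, beyond the scatter, with 1H-imidazol-1-yl in place of 1H-pyrazol-1-yl. The ring here can therefore matter a great deal, and compound 2 at 2340 nM shows that another ring at this place gives a measurable number. A large expected step is an at least 7.5-fold lower number from compound 3 to compound 4 (0.87 log units; beyond the scatter) in this assay toward a lower number, although the limit leaves its exact size open. For compound 4 the estimated value is 4000 nM with an expected range from 1000 nM to 20000 nM in this assay by this estimate.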

Compound 4, half-maximal inhibitory concentration: 1270 nM
Compound 4: the middle estimate sits 3.1-fold (0.50 log units) above what was measured, and the stated range covers the measured number.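

In this assay, pyridin-3-yl gives a measurable number at this place, on an aromatic carbon meta to a large group and para to a methyl group, with an at least 23-fold lower number from compound 3 to compound 4 (1.37 log units; beyond the scatter). On these data alone, compound 3 carries only a limit, so the exact size of that step stays open: the limit of > 30000 nM in this assay, at which 1 of the 4 values shown sits. Pyridin-3-yl and 1H-pyrazol-1-yl cannot be told apart here, with a 1.8-fold lower number from compound 2 to compound 4 (0.27 log units; within the scatter), so a six-membered and a five-membered aromatic ring both give a measurable number, and among these three rings only 1H-imidazol-1-yl stands apart.

The compounds shown leave open whether pyridin-2-yl or pyridin-4-yl would match pyridin-3-yl. They also leave open whether a group without an aromatic ring, such as an amine or a carboxylic acid, would give a measurable number at this place.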